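The source may hold more compounds than are shown below. What is called first, only, known or untested is meant among the compounds shown, and "the series" means these compounds.

Compound 3 `Nc1ccc2cccc(OC3CCCC3)c2n1` is recorded in an assay on cells with melanin-concentrating hormone receptor 1 (Homo sapiens) as the target, read by radioligand binding (a higher number here means a weaker inhibitor, a lower number a stronger inhibitor), only as > 2000 nM, a limit of the assay and not a number (the limit of > 2000 nM in this assay, at which 1 of the 3 values shown sits). Compound 1 `Nc1ccc2cccc(OCC3CCOC3)c2n1` gives 115 nM in this assay. Compound 2 `Nc1ccc2cccc(OCC3CCC3)c2n1` gives 432 nM in this assay. The measured steps run an at least 17-fold higher number from compound 1 to compound 3 (1.24 log units; beyond the scatter) and an at least 4.6-fold higher number from compound 2 to compound 3 (0.66 log units; beyond the scatter), both losses into the cyclopentyl ether, while a 3.8-fold higher number from compound 1 to compound 2 (0.57 log units; beyond the scatter) separates the two ethers. Compound 4 `CSCCOc1cccc2ccc(N)nc12` makes the change (2-(methylsulfanyl)ethyl in place of cyclopentyl on an oxygen on an aromatic ring). Since both measured steps into compound 3 were at least modest losses, leaving the cyclopentyl for an open chain is expected to recover a good part of them, though how much remains uncertain. Compound 4 is therefore expected at about 350 nM in this assay, within 110 nM to 1500 nM, which means an expected step of an at least 5.7-fold lower number from compound 3 to compound 4 (0.75 log units; beyond the scatter).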

Compound 4, half-maximal inhibitory concentration: > 2000 nM
Compound 4: only a limit was reported; the forecaster's own chance of this, stated with the estimate: 12%; at least 5.7-fold (0.75 log units) between middle value and limit.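

In this assay compound 4 is recorded only as > 2000 nM, a limit of the assay, so the open 2-(methylsulfanyl)ethyl chain on this oxygen does not bring back a measurable value. The result is an at least 4.6-fold higher number from compound 2 to compound 4 (0.66 log units; beyond the scatter) and an at least 17-fold higher number from compound 1 to compound 4 (1.24 log units; beyond the scatter), so among the four ethers only compound 1 and compound 2, each with a ring on a saturated chain carbon, give numbers. The step between compound 3 and compound 4 cannot be read: the limit of > 2000 nM in this assay, at which 2 of the 4 values shown sit.

Open, on these data alone, is how a 2-methoxyethyl chain or an aminoethyl chain on this oxygen would read in this assay. Also open, as far as these compounds go, is whether compound 3 and compound 4 differ at all beyond the limit.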